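Cyclohexyl for phenyl on the shared core, propargyl series

This account rests on a few compounds, and the source may have more. Where it says the series, first, only, none or still open, it means among the compounds named here.

Two compounds of this series have numbers in an assay on cell membranes from brain for binding affinity to adenosine receptor A1 (Rattus norvegicus), read by radioligand binding; on this read-out higher numbers stand for weaker inhibition and lower numbers for stronger inhibition. Compound 1 `CCn1c(=O)[nH]c2[nH]c(C3CCCCC3)nc2c1=O` carries ethyl on the shared core together with cyclohexyl; in this assay compound 1 gives 76 nM. Compound 2 `C#CCn1c(=O)[nH]c2[nH]c(-c3ccccc3)nc2c1=O` carries propargyl together with phenyl; in this assay compound 2 gives 210 nM. Compound 2 thus stands at the higher of the two numbers, and its gap to compound 1 lies beyond the scatter. Compound 1 and compound 2 differ in two places at once, so no single step can be read from their pair.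

Compound 3 `C#CCn1c(=O)[nH]c2[nH]c(C3CCCCC3)nc2c1=O` is not yet measured. Relative to compound 2 the change is cyclohexyl in place of phenyl on an aromatic carbon, with the propargyl kept. Among the compounds with values here, the only guide is compound 1, which carries the same cyclohexyl and gives 76 nM; on that basis the number for compound 3 is expected to come out lower than that of compound 2, by a step of about a 3.0-fold lower number from compound 2 to compound 3 (0.48 log units; beyond the scatter). The estimate for compound 3 in this assay is 70 nM, with a range from 20 nM to 250 nM.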

Compound 3, inhibition constant: 170 nM
Compound 3: middle estimate off by 2.4-fold (0.39 log units), on the low side, within the range that was stated.
By their numbers in this assay, from the lowest: compound 1; then compounds 3 and 2 (each within the scatter of the next).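

In this assay with the propargyl kept on the shared core, cyclohexyl in place of phenyl on the aromatic carbon between two ring nitrogen atoms gives a 1.2-fold lower number from compound 2 to compound 3 (0.09 log units; within the scatter) and so leaves no readable difference at this position between the non-aromatic ring and the aromatic ring of carbon only, each of 6 heavy atoms. With the cyclohexyl kept, ethynyl in place of methyl on the saturated chain carbon bound to an aromatic nitrogen gives a 2.2-fold higher number from compound 1 to compound 3 (0.35 log units; beyond the scatter) as a modest step, which makes the chain, and not the ring position, the one place where a change among these compounds reads beyond the scatter. No measurement at hand bears on the reason for either step. 

The compounds shown leave open whether cyclohexyl and phenyl also match when ethyl stands on the chain, so the two steps cannot yet be checked against each other. They also leave open how this position responds to groups of a different kind, such as an amine or a carboxylic acid, and how the chain position responds to a longer chain such as butyl.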